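The compounds below may be only part of what the source reports. "The series", "measured", "known", "first", "only" and "open" are said of these compounds alone.

Working notes on the series. Compound 1 `COCCCN1CCC2(CCN(C(c3ccc(F)cc3)c3ccc(F)cc3)CC2)C1=O` gives 44% in a functional assay on cells for antagonist activity at Voltage-dependent T-type calcium channel subunit alpha-1H (Homo sapiens), read by patch clamp, tested at 1 uM; on this read-out higher numbers stand for more inhibition at the one concentration tested (going by the name of the read-out) and lower numbers for less inhibition. Among the compounds with values here, compound 2 `CC(C)OCCCN1CCC2(CCN(C(c3ccc(F)cc3)c3ccc(F)cc3)CC2)C1=O` gives 76% in this assay, the highest of the two numbers so far; its nearest neighbour is compound 1, with the step of a number 32 percentage points higher from compound 1 to compound 2 (beyond the scatter). Compound 3 `O=C1NCCC12CCN(C(c1ccc(F)cc1)c1ccc(F)cc1)CC2` has not yet been measured in this assay. The change from compound 2 to compound 3: hydrogen in place of 3-isopropoxypropyl on an amide-type nitrogen in a ring. Within the data shown here, only one measured step bears on this position. It is the exchange on the oxygen of that same chain, a number 32 percentage points higher from compound 1 to compound 2 (beyond the scatter), which was large, so this place on the core is sensitive to what is attached. Taking away the whole chain goes further than that step. It is expected that compound 3 therefore drops in this assay by a number 56 percentage points lower from compound 2 to compound 3 (beyond the scatter), beyond the scatter. The estimate for compound 3 in this assay is 20%, with a range from 0% to 50%.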

Compound 3, a percentage reported as inhibition, at one concentration (the size of the read-out at that concentration, not a potency): "not active" (no number reported)
For compound 3 the study gives words and no number; no gap can be computed for the estimate.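

Within the data shown here, compound 3 is reported in this assay only in words, as not active, so no step from compound 2 to compound 3 can be read. The compounds shown leave open how inhibition changes with chains other than 3-isopropoxypropyl on the amide-type nitrogen. No measured evidence bears on this result.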